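A few compounds are considered here, and "the series" means these few. Any claim that something is new, unique, unknown or untested is made for them only; others in the source may bear on it.

Working notes on the series. Two compounds carry numbers in a functional assay on MDA-MB-468 cells (Homo sapiens) for antiproliferative activity, read by MTT assay, with a stated time of 48 h; a higher number here means a weaker inhibitor, a lower number a stronger inhibitor. Compound 1 `CCCNc1cc2c(cn1)cc(NC(=O)c1cccc(-c3ccccc3)c1)c(=O)n2C` gives 1870 nM in this assay. Going by the values given here, compound 2 `COc1cccc(C(=O)Nc2cc3cnc(NCCN(C)C)cc3n(C)c2=O)c1` gives 17400 nM in this assay, the highest of the two numbers; its gap to compound 1 lies beyond the scatter, but the two compounds differ in more than one place, so the comparison shows only the two values and no single-point step. Compound 3 `CN(C)CCNc1cc2c(cn1)cc(NC(=O)c1cc3ccccc3s1)c(=O)n2C` is not yet measured. It keeps the core and the amine of compound 2 and changes only the group on the amide carbonyl: 1-benzothiophen-2-yl in place of 3-methoxyphenyl on a carbonyl carbon. Among the compounds with values here, no measured pair isolates an exchange of this kind at the carbonyl carbon, so the size of the step can only be guessed loosely. Within the data shown here, the entering group is a bicyclic aromatic, and the one measured compound with a larger aromatic group on the amide, compound 1, sits at the lower number, which is taken as weak support for a downward move. Compound 3 is expected to give 5000 nM in this assay, with a range of 1200 nM to 20000 nM. The expected step is a 3.5-fold lower number from compound 2 to compound 3 (0.54 log units; beyond the scatter), downward and modestly beyond the scatter, with wide uncertainty.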

Compound 3, half-maximal inhibitory concentration: 3570 nM
Compound 3: the middle estimate sits 1.4-fold (0.15 log units) above what was measured; the range from low to high includes it.
By their numbers in this assay, from the lowest: compounds 1 and 3 (each within the scatter of the next); then compound 2.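

Going by these compounds alone, the exchange of 3-methoxyphenyl for 1-benzothiophen-2-yl on a carbonyl carbon whose other neighbour is an amide-type nitrogen gives the first single-point reading: in this assay the change gives a 4.9-fold lower number from compound 2 to compound 3 (0.69 log units; beyond the scatter). This shows that the number responds to the group at this place while the core and the amine stay fixed, but the entering group differs from the leaving group in its heavy atoms, its ring count and its hetero atom, and this one step cannot separate these differences. Nothing at hand accounts for the size of the step.

As far as these compounds go, it remains open which part of 1-benzothiophen-2-yl carries the step; a thiophen-2-yl group, or a 1-benzofuran-2-yl group with oxygen in place of sulfur, on the same carbonyl carbon would begin to separate the fused six-membered ring from the hetero atom. The contribution of the amine also cannot be read, since compound 1 differs from compound 2 and from compound 3 in more than one place, and a propylamine paired with the 1-benzothiophen-2-yl amide would isolate that exchange.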